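A shorter hydroxycarbamoyl chain on compound 3

The source may hold more compounds than are shown below. What is called first, only, known or untested is meant among the compounds shown, and "the series" means these compounds.

- compound 1 `Nc1nc2cc(-c3nn(CCC(=O)NO)c4ncnc(N)c34)ccc2o1` gives > 150000 nM (a limit)
- compound 2 `Nc1nc2cc(-c3nn(CCCCCC(=O)NO)c4ncnc(N)c34)ccc2o1` gives 37600 nM

Going by the values given here, in a functional assay on CNE-2 cells (Homo sapiens) for inhibition, read by MTT assay, with a stated time of 72 h (a lower number here means a stronger inhibitor, a higher number a weaker inhibitor), compound 2 gives 37600 nM and holds the only true number so far. The other value shown is a limit. Compound 3 `Nc1nc2cc(-c3nn(CC(=O)NO)c4ncnc(N)c34)ccc2o1` shortens the chain of compound 2: hydroxycarbamoyl in place of 4-(hydroxycarbamoyl)butyl on a saturated chain carbon bound to an aromatic nitrogen (hydroxycarbamoyl in place of 4-(hydroxycarbamoyl)butyl). Among the compounds with values here, one measured step bears on this change: an at least 3.9-fold lower number from compound 1 to compound 2 (0.60 log units; beyond the scatter) (there the longer chain gave the lower number). A shortening is therefore expected to raise the number in this assay by a similar or greater amount. The change expected is a 4.0-fold higher number from compound 2 to compound 3 (0.60 log units; beyond the scatter) (an estimate). The estimated value for compound 3 is 150000 nM within an expected range of 60000 nM to 400000 nM (possibly reported only as a limit).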

Compound 3, half-maximal inhibitory concentration: 12200 nM
For compound 3 the middle estimate is 12-fold (1.09 log units) above the measured one, outside the stated range (below it).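

In this assay, the shortest chain does not raise the number as the first step suggested; it gives a 3.1-fold lower number from compound 2 to compound 3 (0.49 log units; beyond the scatter). The second new step, an at least 12-fold lower number from compound 1 to compound 3 (1.08 log units; beyond the scatter), shows that the order does not follow chain length at this saturated chain carbon bound to an aromatic nitrogen, since the intermediate chain of compound 1 stands highest and the shortest chain lowest. Compound 1 remains a limit, not a number: the limit of > 150000 nM in this assay, at which 1 of the 3 values shown sits.

Going by these compounds, whether a chain longer than 5-(hydroxycarbamoyl)pentyl would lower the number again stays open. So does whether a carboxylic acid or an amine at the chain end would follow the same order.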